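This account rests on a few compounds, and the source may have more. Where it says the series, first, only, none or still open, it means among the compounds named here.

Three compounds share one core, a chain that carries a carbonyl group joined to a halogenated benzene ring, and differ only in that ring. Compound 1 `N=C(N)N/N=C/c1ccc(/C=C/C(=O)c2ccc(Br)cc2)cc1` carries a 4-bromophenyl group, compound 2 `N=C(N)N/N=C/c1ccc(/C=C/C(=O)c2ccc(Cl)cc2)cc1` a 4-chlorophenyl group, and compound 3 `N=C(N)N/N=C/c1ccc(/C=C/C(=O)c2ccccc2Cl)cc1` a 2-chlorophenyl group. In a functional assay on the whole organism (Ear) for inhibition, with Mus musculus as the target, with a stated time of 30 min, at a dose of 100 mg/kg by the intraperitoneal route (on this read-out higher numbers stand for more inhibition at the one dose given (going by the name of the read-out) and lower numbers for less inhibition), compound 1 gives 68.9%. In this assay compound 2 gives 56.4%, and compound 3 gives 84.1% in this assay. Going from compound 2 to compound 1 the change is bromo in place of chloro on an aromatic carbon, and it made a step of a number 12.5 percentage points higher from compound 2 to compound 1 (beyond the scatter). The cores of compound 2 and compound 3 differ by 2-chlorophenyl in place of 4-chlorophenyl on a carbonyl carbon, a change that gave a number 27.7 percentage points higher from compound 2 to compound 3 (beyond the scatter).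

Compound 4 `N=C(N)N/N=C/c1ccc(/C=C/C(=O)c2ccccc2Br)cc1` has not yet been measured. From compound 3 it differs by bromo in place of chloro on an aromatic carbon. Among the measured compounds shown here, this is the same kind of change as the one from compound 2 to compound 1, but not the same: there the halogen sat para to a large group, here it sits ortho to a large group. Beside the earlier step, the step from compound 3 to compound 4 is expected to be a number 5.9 percentage points higher from compound 3 to compound 4 (within the scatter), a little smaller, resting on compound 1 having shown a number 12.5 percentage points higher from compound 2 to compound 1 (beyond the scatter) over compound 2 and on compound 3 already standing at 84.1%, which leaves little room upward. Compound 4 is therefore estimated to give 90%, most likely between 78% and 99%.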

Compound 4, a percentage reported as inhibition, in the whole organism at one dose (the size of the read-out at that dose, not a potency): 78.3%
Beside the measured number, compound 4's estimate is 11.7 percentage points above it; measured number inside the range.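

Swapping chloro for bromo on an aromatic carbon does not carry over as a fixed step from one core to another in this assay: the same change on two cores in this assay, a number 12.5 percentage points higher (beyond the scatter) from compound 2 to compound 1 and a number 5.8 percentage points lower (within the scatter) from compound 3 to compound 4, 18.3 percentage points apart, beyond the scatter of two such steps

With the halogen ortho to a large group, the swap gives a step of a number 5.8 percentage points lower from compound 3 to compound 4 (within the scatter), so on this core the two halogens cannot be told apart, even though the same swap made a clear difference on the core of compound 2. Comparing the two halogen placements gives a number 21.9 percentage points higher from compound 2 to compound 4 (beyond the scatter) for the chloro-to-bromo pair with the placement also changed, but only a number 9.4 percentage points higher from compound 1 to compound 4 (within the scatter) when bromo stays on the ring and only its place changes, so the lift seen with the 2-chlorophenyl group does not clearly repeat with bromo. Two pairs show that the effect of this swap depends on its surroundings, but they do not show why, and they give no rule for any further core.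

The compounds shown carry only chloro and bromo on this ring, so what a fluoro, a methoxy or a carboxylic acid group would give there stays open. Every number also comes from a single dose, which leaves open how these compounds would compare across a range of doses.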